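Changing the aryl group on a four-membered ring core

The source may report more compounds than this note shows. Statements on the series, on what has been measured and on what is new or still open speak of the compounds shown alone.

Measured compounds:
Compound 1 `CCOC(=O)/C(=C/c1ccccc1)CN1C(=O)[C@@H](OC)[C@H]1c1ccc(Cl)cc1`: 11100 nM
Compound 2 `COC(=O)/C(=C/c1ccccc1)CN1C(=O)[C@@H](OC)[C@H]1c1cccc(F)c1`: 34400 nM

Of the compounds shown here, two have been tested in a functional assay on MDA-MB-231 cells (Homo sapiens) for antiproliferative activity, read by MTT assay, with a stated time of 48 h; a higher number here means a weaker inhibitor, a lower number a stronger inhibitor. Compound 1 gives 11100 nM in this assay, while compound 2 gives 34400 nM. Compound 2 therefore stands at the highest of the two numbers, so it is the weaker inhibitor of the pair, and its gap to compound 1 lies beyond the usual scatter. The two compounds differ in more than one place, so the numbers alone cannot be traced to a single change.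

Compound 3 `COC(=O)/C(=C/c1ccccc1)CN1C(=O)[C@@H](OC)[C@H]1c1ccc(OC)cc1` has not yet been measured. It differs from compound 2 in one place: 4-methoxyphenyl in place of 3-fluorophenyl on a saturated ring carbon. Going by the values given here, no single-change step between measured compounds is available to guide this. Compound 3 is expected to give a number somewhat lower than compound 2, a step of modest size, a 1.7-fold lower number from compound 2 to compound 3 (0.24 log units; within the scatter), which may not clearly exceed the scatter. The estimate for compound 3 in this assay is 20000 nM, with a range from 7000 nM to 60000 nM.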

Compound 3, half-maximal inhibitory concentration: 14000 nM
Estimate against measurement, compound 3: 1.4-fold (0.15 log units) above; the range from low to high includes it.
By their numbers in this assay, from the lowest: compounds 1 and 3 (each within the scatter of the next); then compound 2.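

Going by these compounds alone, this is the first single change on the shared core that can be read: in this assay, placing 4-methoxyphenyl where 3-fluorophenyl stood on the saturated ring carbon gives a 2.5-fold lower number from compound 2 to compound 3 (0.39 log units; beyond the scatter) with the rest of the molecule unchanged. The aryl group at this position therefore affects the read-out, and although the step is modest, it lies beyond the usual scatter of repeated measurements. No measurement is available that explains this step.

The change replaces fluorine with a methoxy group and also shifts the substituent to the ring position given in the new group's name, and these two compounds cannot show how much of the step belongs to each part. The compounds shown also leave open how the number would respond to an amine or a carboxylic acid on this phenyl ring, or to a longer chain in place of the methoxy group.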